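The source may report more compounds than this note shows. Statements on the series, on what has been measured and on what is new or still open speak of the compounds shown alone.

In a functional assay on HT-1080 cells (Homo sapiens) for antiproliferative activity, read by sulforhodamine B assay, with a stated time of 48 h (a lower number here means a stronger inhibitor, a higher number a weaker inhibitor), compound 1 `Cc1cc(NS(=O)(=O)c2ccc(N/C(S)=N\c3ccnc4cc(C(F)(F)F)ccc34)cc2)on1` gives 27300 nM, and compound 2 `Cc1ccnc(NS(=O)(=O)c2ccc(N/C(S)=N\c3ccnc4cc(C(F)(F)F)ccc34)cc2)n1` gives 28700 nM. The step of a 1.1-fold higher number from compound 1 to compound 2 (0.02 log units; within the scatter) is therefore small, and compound 2 stands at the upper end of the two numbers shown, with compound 1 sitting within the scatter of it. The pair shows that exchanging one heteroaryl group on the sulfonamide nitrogen for another leaves the number in this assay essentially where it was.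

Compound 3 `COc1ncnc(NS(=O)(=O)c2ccc(N/C(S)=N\c3ccnc4cc(C(F)(F)F)ccc34)cc2)c1OC` takes this exchange one step further: 5,6-dimethoxypyrimidin-4-yl in place of 4-methylpyrimidin-2-yl on a sulfonamide nitrogen. Going by the values given here, only the single step from compound 1 to compound 2 bears on this change, and that step was within the scatter; no measured pair shows how a methoxy-bearing ring on this nitrogen behaves, so the expectation rests on the shared core and the one precedent. For compound 3 the expected step is a 1.0-fold higher number from compound 2 to compound 3 (0.02 log units; within the scatter), meaning no movement beyond the scatter in either direction. On that basis compound 3 is estimated at 30000 nM, within a range from 12000 nM to 75000 nM.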

Compound 3, half-maximal inhibitory concentration: 22800 nM
Compound 3: the middle estimate sits 1.3-fold (0.12 log units) above what was measured, within the range that was stated.
By their numbers in this assay, from the lowest: compounds 3, 1 and 2 (each within the scatter of the next).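

In this assay, a third heteroaryl group on the sulfonamide nitrogen again leaves the number within the scatter, with a 1.3-fold lower number from compound 2 to compound 3 (0.10 log units; within the scatter) and a 1.2-fold lower number from compound 1 to compound 3 (0.08 log units; within the scatter). Going by these compounds alone, the first pair compared only two methyl-bearing rings, whereas 5,6-dimethoxypyrimidin-4-yl replaces the methyl-bearing ring of compound 2 with a ring carrying two methoxy groups, going from 7 to 10 heavy atoms and from 2 to 4 hydrogen-bond acceptors, and even this larger exchange does not take the number beyond the scatter, so across these three compounds the identity of the heteroaryl group at this position makes no readable difference in this assay. No measurement is available that could explain this insensitivity.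

The compounds shown leave open whether the same holds for a group on that nitrogen with no ring at all, such as a plain methyl or a 2-aminoethyl chain, or for a ring bearing a carboxylic acid. They also leave open how the number responds to a change elsewhere, for instance chlorine in place of the trifluoromethyl group that all three compounds share.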